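This account rests on a few compounds, and the source may have more. Where it says the series, first, only, none or still open, it means among the compounds named here.

Working notes on the hydroxamic acid series in a functional assay on A2780 cells (Homo sapiens) for cytotoxicity, read by MTT assay, with a stated time of 72 h; on this read-out lower numbers stand for stronger inhibition and higher numbers for weaker inhibition.

Of the compounds shown here, two carry numbers so far. Compound 1, `CN(C)c1ccc(C(=O)N(CCCCCC(=O)NO)CC(=O)NC(C)(C)C)cc1`, gives 1030 nM. Compound 2, `O=C(CCCCCN(CC(=O)NC1CCCCC1)C(=O)c1ccccc1)NO`, gives 3460 nM, the higher of the two numbers, with compound 1 the lower by a margin beyond the scatter. Compound 1 and compound 2 differ in two places at once, so the two values alone do not say which change carries the gap.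

Compound 3, `CC(C)(C)NC(=O)CN(CCCCCC(=O)NO)C(=O)c1ccccc1`, has not been measured. It differs from compound 2 in one place: tert-butyl in place of cyclohexyl on an amide-type nitrogen. Compound 1 also carries a tert-butyl on that nitrogen, but its other difference from compound 2 leaves the contribution of this group open.

With no single-change step shown, the step from compound 2 to compound 3 is expected to be small, in no direction beyond the scatter, a 1.2-fold lower number from compound 2 to compound 3 (0.09 log units; within the scatter). Compound 3 is accordingly estimated at 2800 nM, with a range from 1300 nM to 6000 nM.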

Compound 3, half-maximal inhibitory concentration: 20700 nM
For compound 3 the middle estimate is 7.4-fold (0.87 log units) below the measured one; the measured number lies above the stated range.
By their numbers in this assay, from the lowest: compound 1; then compound 2; then compound 3.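

In this assay, the group on the amide-type nitrogen turns out to matter in its own right: with hydrogen on the aromatic carbon held constant, tert-butyl in place of cyclohexyl gives a 6.0-fold higher number from compound 2 to compound 3 (0.78 log units; beyond the scatter), a modest step. Compound 3 also separates the two changes that were mixed between compound 1 and compound 2: with tert-butyl held constant, hydrogen in place of dimethylamino on an aromatic carbon gives a 20-fold higher number from compound 1 to compound 3 (1.30 log units; beyond the scatter), a large step, so that aromatic position also carries weight in this series. No measurement at hand bears on the reason for either step.

As far as these compounds go, whether dimethylamino has the same effect alongside cyclohexyl remains open, so the two steps cannot yet be taken as independent. From the compounds shown here alone, it is also open where cyclopentyl or an n-butyl chain on the amide-type nitrogen would fall relative to cyclohexyl and tert-butyl, and whether methoxy on the aromatic carbon would track dimethylamino.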